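Oximes with varied side chains: lipophilicity notes

A few compounds are considered here, and "the series" means these few. Any claim that something is new, unique, unknown or untested is made for them only; others in the source may bear on it.

Compound 1: `C[n+]1ccn(CCCC#N)c1/C=N/O`, a physicochemical assay for lipophilicity; on this read-out lower numbers stand for lower lipophilicity and higher numbers for higher lipophilicity < -3
Compound 2: `C[n+]1ccn(CCCCOC(=O)c2ccccc2O)c1/C=N/O`, this assay -0.56

In this assay compound 1 returns only a limit, < -3, so its true position is not fixed by a number. Compound 2 gives a numerical reading of -0.56 in this assay. Of the two values shown, one sits at the limit (the limit of < -3 in this assay, at which 1 of the 2 values shown sits). Among the measured compounds shown here, no step between measured compounds is available, as the two differ in more than one place, so only the two readings themselves can be stated.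

Compound 3, `C[n+]1ccn(CCN2CCCC2)c1/C=N/O`, has not yet been measured in this assay. It differs from compound 1 by pyrrolidin-1-yl in place of cyanomethyl on a saturated chain carbon, two bonds along the chain from an aromatic nitrogen. Because compound 1 sits at < -3, any change in this assay can only be read upward or as no change, and a modest upward movement is expected here, a number at least 0.20 log units higher from compound 1 to compound 3 (that floor lies within the scatter), of a size that may not be resolved beyond the scatter if the reading again falls at the limit. Compound 3 is therefore estimated at -2.8, within a range from -3.8 to -1.8, with a real chance that this assay again reports only a limit.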

Compound 3, distribution coefficient: -2.73
Beside the measured number, compound 3's estimate is 0.07 log units below it; measured number inside the range.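

Among the compounds shown here, this is the first comparison that turns on one place: on a saturated chain carbon, two bonds along the chain from an aromatic nitrogen, pyrrolidin-1-yl in place of cyanomethyl gives a number at least 0.27 log units higher from compound 1 to compound 3 (that floor lies within the scatter) in this assay. Compound 1 stands at < -3, which is a limit of the assay and not a number. The step is therefore only a floor, its true size cannot be read, and it does not show how far the exchange moves the reading: the limit of < -3 in this assay, at which 1 of the 3 values shown sits.

Still open, from the compounds shown here alone, is whether another amine at this place, such as piperidine or dimethylamino, or a carboxylic acid, would read apart from compound 3 in this assay, and how pyrrolidin-1-yl would read on a longer chain. For the compounds shown here, compound 3 and compound 2 differ in more than one place, so no step links them and the part played by the side chain of compound 2 remains unresolved.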